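Swapping a dimethylamino ring for a chlorinated one

The source may report more compounds than this note shows. Statements on the series, on what has been measured and on what is new or still open speak of the compounds shown alone.

Compound 1 `O=C1/C(=C\c2ccccc2Cl)c2ccccc2N1c1c(Cl)cccc1Cl` gives > 100 ug/mL in a functional assay on MIA PaCa-2 cells (Homo sapiens) for cytotoxicity, read by MTT assay, with a stated time of 72 h (a higher number here means that more compound is needed for the effect, a lower number that less compound is needed), which is a limit of the assay and not a number.
Compound 2 `CN(C)c1ccc(/C=C2\C(=O)N(c3c(Cl)cccc3Cl)c3ccccc32)cc1` gives > 100 ug/mL in this assay, again a limit and not a number.

Compound 2 therefore stands at the edge of what this assay can report, and so does compound 1. Within the data shown here, both values sit at the same limit, so the single measured step that the two limits leave unreadable from compound 1 to compound 2 has no readable size, because the limit of > 100 ug/mL in this assay, at which 2 of the 2 values shown sit, leaves no number on either side.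

Compound 3 `O=C1/C(=C\c2cccc(Cl)c2)c2ccccc2N1c1c(Cl)cccc1Cl` differs from compound 2 in one place: 3-chlorophenyl in place of 4-(dimethylamino)phenyl on a double-bonded chain carbon bound to a double-bonded ring carbon. Among the measured compounds shown here, the only measured step that bears on this change is a step that the two limits leave unreadable from compound 1 to compound 2, and it is unreadable. For the measured compounds named here, compound 1, which carries a 2-chlorophenyl at this place, also sits at the limit, and nothing among the measured values points to a readable step in either direction for a chlorinated ring here. Compound 3 is thus expected to sit at the limit again, with an estimate of 150 ug/mL and a range from 50 ug/mL to 450 ug/mL. The step expected here is a step that the limit leaves unreadable from compound 2 to compound 3, most likely nothing beyond the scatter.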

Compound 3, concentration for half-maximal effect: 5 ug/mL
For compound 3 the middle estimate is 30-fold (1.48 log units) above the measured one, outside the stated range (below it).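

The position on the double-bonded chain carbon bound to a double-bonded ring carbon can clearly change the result in this assay, which the earlier pair could not show, as the step between them cannot be read. Replacing 4-(dimethylamino)phenyl with 3-chlorophenyl gives an at least 20-fold lower number from compound 2 to compound 3 (1.30 log units; beyond the scatter), and replacing 2-chlorophenyl with 3-chlorophenyl gives an at least 20-fold lower number from compound 1 to compound 3 (1.30 log units; beyond the scatter). The second step is the more telling one: a chlorinated ring alone does not give a measurable value here, and 3-chlorophenyl and 2-chlorophenyl, which differ only in where the chlorine sits on the ring, give clearly different results, though the true size of both steps stays unknown with a limit on one side of each: the limit of > 100 ug/mL in this assay, at which 2 of the 3 values shown sit.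

The compounds shown leave open whether the result depends on chlorine at all, since an unsubstituted phenyl or a 3-methoxyphenyl at this place would test that. They also leave open how 4-chlorophenyl would compare, which would show whether 3-chlorophenyl is the only chlorophenyl of the three to give a measurable value.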